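Compound 4 and the limit of the cytotoxicity assay

This account rests on a few compounds, and the source may have more. Where it says the series, first, only, none or still open, it means among the compounds named here.

Measured in a functional assay on HT-29 cells (Homo sapiens) for cytotoxicity, read by MTT assay, with a stated time of 72 h; on this read-out lower numbers stand for stronger inhibition and higher numbers for weaker inhibition:
- compound 1 `NCCCNc1c(C(=O)NCc2ccc(F)cc2)nc(Br)c2cccnc12`: "not determined" (no result reported)
- compound 2 `Nc1ccc(Nc2c(C(=O)NCc3ccc(F)cc3)nc(Br)c3cccnc23)cc1`: > 10000 nM
- compound 3 `O=C(NCCCNc1c(C(=O)NCc2ccc(F)cc2)nc(Br)c2cccnc12)c1ccccc1`: > 10000 nM

The position of compound 3 is known only as a limit, since compound 3 gives > 10000 nM in this assay, and that entry is not a number. Compound 2 gives > 10000 nM, which is likewise a limit. For compound 1 the entry reads "not determined" (no result reported). Within the data shown here, the series therefore offers no true number to compare, and no two measured compounds differ in one place.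

Compound 4 `CNCCCNc1c(C(=O)NCc2ccc(F)cc2)nc(Br)c2cccnc12` has yet to be measured. It departs from compound 3 as follows: methyl in place of benzoyl on an amine nitrogen. In short, compound 4 carries a small methyl group where compound 3 has its larger benzoyl group.

Among the measured compounds shown here, with no measured step as a guide, no change beyond the scatter is expected in this assay, although a modest move toward stronger inhibition remains possible. The expectation stays close to the limit because of the limit of > 10000 nM in this assay, at which 2 of the 3 values shown sit, which covers compound 2 and compound 3 alike. The expected step, taken against a limit and not a number, is an at least 1.2-fold lower number from compound 3 to compound 4 (0.09 log units; that floor lies within the scatter). For compound 4 the estimated value is 8000 nM, with an expected range from 2000 nM to 30000 nM.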

Compound 4, half-maximal inhibitory concentration: > 10000 nM
Compound 4 ended at the assay's limit; the forecaster's own chance of this, stated with the estimate: 55%; at least 1.2-fold (0.09 log units) between middle value and limit.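

In this assay compound 4 gives > 10000 nM, which is a limit and not a number. Among these compounds, compound 2, compound 3 and compound 4 all stand at limits, and no step among them can be read. The compounds shown leave open how strongly any of them inhibits, with no true number among them: the limit of > 10000 nM in this assay, at which 3 of the 4 values shown sit.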